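Methyl for bromo on the aryl ring of the thioenol series

The compounds below may be only part of what the source reports. "The series", "measured", "known", "first", "only" and "open" are said of these compounds alone.

Three compounds share one core. Compound 1 `CN1C(=O)/C(=C(/S)N(C)c2ccccc2)C(=O)c2cc(Cl)ccc21` is the unsubstituted phenyl member; compound 2 `CN1C(=O)/C(=C(/S)N(C)c2ccc(Br)cc2)C(=O)c2cc(Cl)ccc21` carries bromo on that ring; compound 3 `Cc1ccc(N(C)/C(S)=C2/C(=O)c3cc(Cl)ccc3N(C)C2=O)cc1` is not yet measured. In a functional assay on the whole organism for inhibition, with Mus musculus as the target, at a dose of 10 mg/kg by the oral route (a lower number here means less inhibition, a higher number more inhibition at the dose given (going by the name of the read-out)), compound 1 gives 64%; 64% (2 entries) in two entries. In this assay, going by the values given here, compound 2 gives 50%, its only number, with a further entry that yields no single value. Among the compounds with values here, no step between measured compounds is given, so what compound 1 and compound 2 show is only that their two values lie within the usual scatter of each other. The change from compound 2 to compound 3 is methyl in place of bromo on an aromatic carbon. With nothing to anchor a direction, the step of a number 5 percentage points higher from compound 2 to compound 3 (within the scatter) is expected to stay within the scatter, rather than move clearly up or down. Compound 3 is therefore estimated at 55%, with a range from 35% to 75%.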

Compound 3, a percentage reported as inhibition, in the whole organism at one dose (the size of the read-out at that dose, not a potency): 23%
For compound 3 the middle estimate is 32 percentage points above the measured one; measured number below the stated range.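

In this assay the group on this aromatic carbon matters: going from bromo to methyl gives a number 27 percentage points lower from compound 2 to compound 3 (beyond the scatter) even though one heavy atom replaces one heavy atom, and the counts of hydrogen-bond donors, acceptors and net charge stay the same. Going by these compounds alone, this is the first readable step, so the 4-bromophenyl to 4-methylphenyl change is not interchangeable at this position, para to a large group. No measurement at hand accounts for the size or direction of this step.

As far as these compounds go, with only bromo and methyl compared directly, it remains open whether the outcome follows a trend across substituents or is specific to methyl. A chloro, methoxy or carboxylic acid group at the same position could show whether values fall nearer compound 2 or compound 3.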